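Swapping Nitro for Isopropyl on a Pyridyl Urea

This account rests on a few compounds, and the source may have more. Where it says the series, first, only, none or still open, it means among the compounds named here.

Compound 1 `O=C(Nc1ccncc1)Nc1ccccc1Br` and compound 2 `O=C(Nc1ccncc1)Nc1ccc([N+](=O)[O-])cc1` share one core and differ only in the group on the outer ring. In a functional assay on the whole organism with Mus musculus as the target, in the maximal electroshock model, with a stated time of 30 min (on this read-out higher numbers stand for an effect only at larger amounts of compound and lower numbers for an effect already at smaller amounts), compound 1 gives 100 mg/kg. Compound 2 shows only a limit of the assay, > 300 mg/kg, as the limit of > 300 mg/kg in this assay, at which 1 of the 2 values shown sits, states. Compound 3 `CC(C)c1ccc(NC(=O)Nc2ccncc2)cc1` carries isopropyl in place of nitro on an aromatic carbon. Among the compounds with values here, no measured step covers this change, and compound 2 itself stands at a limit, so the step is expected to be a drop, beyond the usual scatter, of about an at least 3.0-fold lower number from compound 2 to compound 3 (0.47 log units; beyond the scatter). Compound 3 is estimated at 100 mg/kg, somewhere between 30 mg/kg and 300 mg/kg.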

Compound 3, minimum effective dose: > 300 mg/kg
Compound 3: only a limit was reported (the forecaster's own chance of this, stated with the estimate: 35%); at least 3.0-fold (0.47 log units) between middle value and limit.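

No step can be read from compound 2 to compound 3, because both stand at the same limit of the assay: the limit of > 300 mg/kg in this assay, at which 2 of the 3 values shown sit.

On these data alone, whether isopropyl in place of nitro changes the result in this assay at all stays open.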